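From methylcarbamoyl to isopropylcarbamoyl: compound 1 to compound 4

This account rests on a few compounds, and the source may have more. Where it says the series, first, only, none or still open, it means among the compounds named here.

In an in vivo ADME assay on the whole organism (strain Sprague-Dawley) for pharmacokinetics, with Rattus norvegicus as the target, at a dose of 3 mg/kg by the oral route (a higher number here means that a larger share of the oral dose reaches the circulation, a lower number that a smaller share of the oral dose reaches the circulation), compound 1 `CNC(=O)c1cc(F)ccc1CNC(=O)c1nc(C(C)(C)C)n(C)c(=O)c1O` gives 18%. Compound 2 `Cn1c(C(C)(C)C)nc(C(=O)NCc2ccc(F)cc2S(C)(=O)=O)c(O)c1=O` gives 17%, level with compound 1 within the scatter. Compound 3 `CCNC(=O)c1cc(F)ccc1CNC(=O)c1nc(C(C)(C)C)n(C)c(=O)c1O` gives 30%, the highest of the three. Compound 1 therefore shares the lower level with compound 2.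

The next compound is compound 4 `CC(C)NC(=O)c1cc(F)ccc1CNC(=O)c1nc(C(C)(C)C)n(C)c(=O)c1O`, with the change isopropyl in place of methyl on an amide-type nitrogen. The most relevant measured change is the one at this same amide, a number 12 percentage points higher from compound 1 to compound 3 (beyond the scatter). The other two steps, a number 1 percentage points lower from compound 1 to compound 2 (within the scatter) and a number 13 percentage points higher from compound 2 to compound 3 (beyond the scatter), involve methylsulfonyl and bear on this change only indirectly. Going by the values given here, no measured compound carries isopropyl, and a single step is thin support.

An upward step of similar size is expected, resting on the step of a number 12 percentage points higher from compound 1 to compound 3 (beyond the scatter). The expected change is a number 13 percentage points higher from compound 1 to compound 4 (beyond the scatter). For compound 4 the estimated value is 31%, with an expected range of 16% to 47%.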

Compound 4, oral bioavailability: 44%
The estimate for compound 4 lay 13 percentage points below the measured number, within the range that was stated.
By their numbers in this assay, from the lowest: compounds 2 and 1 (each within the scatter of the next); then compound 3; then compound 4.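

In this assay the rise at this amide-type nitrogen does not stop at ethyl: isopropyl gives a number 14 percentage points higher from compound 3 to compound 4 (beyond the scatter) and the whole change from methyl amounts to a number 26 percentage points higher from compound 1 to compound 4 (beyond the scatter) in these notes. The isopropylcarbamoyl group also stands clear of methylsulfonyl on the aromatic carbon, with a number 27 percentage points higher from compound 2 to compound 4 (beyond the scatter) for that exchange, whereas the methylcarbamoyl of compound 1 stays level with the methylsulfonyl of compound 2, so the substituent on the amide nitrogen decides how this aromatic position compares. Nothing measured on these compounds speaks to why the number climbs along this short sequence.

From the compounds shown here alone, whether the climb continues with tert-butyl or cyclopropyl on the same nitrogen, or reverses with a longer chain such as n-butyl, stays open. Also open, going by these compounds, is whether a second substituent on that nitrogen, as in a dimethylamide, keeps the gain.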